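From Fluoro to Trifluoromethyl on the Shared Core

A few compounds are considered here, and "the series" means these few. Any claim that something is new, unique, unknown or untested is made for them only; others in the source may bear on it.

In a functional assay on HeLa cells (Homo sapiens) for inhibition (a lower number here means a stronger inhibitor, a higher number a weaker inhibitor), compound 1 (`Oc1cccc(-c2cc(-c3ccc(F)cc3)cc(-c3ccccc3O)n2)c1`) gives > 50000 nM as its reading, which is a limit of the assay and not a number. Among the compounds with values here, compound 2 (`Oc1cccc(-c2cc(-c3ccc(F)cc3)cc(-c3cccc(O)c3)n2)c1`) gives 1280 nM as the only true number so far. Within the data shown here, the one measured step is an at least 39-fold lower number from compound 1 to compound 2 (1.59 log units; beyond the scatter) and it is large, yet it comes from 3-hydroxyphenyl in place of 2-hydroxyphenyl, a different change from the next one. Compound 3 (`Oc1cccc(-c2cc(-c3ccc(C(F)(F)F)cc3)cc(-c3cccc(O)c3)n2)c1`) carries trifluoromethyl in place of fluoro on an aromatic carbon. Among the measured compounds shown here, no measured step covers this swap. The expectation therefore rests on compound 2 at 1280 nM alone. The step expected is a 1.0-fold higher number from compound 2 to compound 3 (0.01 log units; within the scatter) and it should stay within the scatter, with no direction favoured. In this assay compound 3 is estimated at 1300 nM (expected range 400 nM to 4500 nM).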

Compound 3, half-maximal inhibitory concentration: > 50000 nM
Compound 3: only a limit was reported; the forecaster's own chance of this, stated with the estimate: 5%; middle value at least 38-fold (1.58 log units) away from the limit.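

Within the data shown here, until now the 4-fluorophenyl group had stayed fixed, and the one measured change lay in a hydroxyphenyl group. Putting trifluoromethyl in place of fluoro, on an aromatic carbon para to a large group, gives an at least 39-fold higher number from compound 2 to compound 3 (1.59 log units; beyond the scatter), so in this assay this position is not indifferent to what it carries. The reading of compound 3 is a limit of the assay and not a number, so the full size of this step stays unknown, and single changes at two different places around compound 2 end at the same limit: the limit of > 50000 nM in this assay, at which 2 of the 3 values shown sit.

On these data alone, only fluoro and trifluoromethyl appear at this position, so it remains open whether chlorine, a methyl group or a methoxy group would keep the level of compound 2. As far as these compounds go, how an amine or a carboxylic acid would fare here is equally open.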